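A Phenyl in Place of a Benzyl: What to Expect

This account rests on a few compounds, and the source may have more. Where it says the series, first, only, none or still open, it means among the compounds named here.

Measured compounds:
compound 1 `O=C1O/C(=C\Cn2cc(Cc3ccccc3)nn2)C(OCc2ccccc2)=C1OCc1ccccc1` — 83100 nM
compound 2 `CCCc1cn(CCC2(O)C(OCc3ccccc3)=C(OCc3ccccc3)C(=O)N2CCC)nn1` — > 100000 nM

Of the compounds shown here, two have been tested in a functional assay on HCT-116 cells (Homo sapiens) for antiproliferative activity, read by MTT assay, with a stated time of 24 h; on this read-out higher numbers stand for weaker inhibition and lower numbers for stronger inhibition. Among the compounds with values here, compound 1 gives 83100 nM, the only actual number in the set. For compound 2 the assay reports only a limit, > 100000 nM, which marks the edge of what the assay can read rather than a measured concentration; this is the situation described by the limit of > 100000 nM in this assay, at which 1 of the 2 values shown sits. Within the data shown here, compound 1 therefore stands as the sole compound with a defined value, and it is a weak inhibitor.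

The next compound, compound 3 `O=C1O/C(=C\Cn2cc(-c3ccccc3)nn2)C(OCc2ccccc2)=C1OCc1ccccc1`, keeps the whole core of compound 1 and changes one group: phenyl in place of benzyl on an aromatic carbon, or 4-benzyl-1H-1,2,3-triazol-1-yl becoming 4-phenyl-1H-1,2,3-triazol-1-yl. Among the measured compounds shown here, no measured pair in this set shows what such a change does, so there is no precedent to lean on. The shift in this assay from compound 1 to compound 3 is expected to be small, a 1.0-fold lower number from compound 1 to compound 3 (0.02 log units; within the scatter), with no clear direction beyond ordinary scatter. Compound 3 is accordingly estimated at 80000 nM, within 30000 nM to 200000 nM.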

Compound 3, half-maximal inhibitory concentration: > 100000 nM
Compound 3: a limit, no number; the forecaster's own chance of this, stated with the estimate: 35%; middle value at least 1.2-fold (0.09 log units) from the limit.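

In this assay, phenyl in place of benzyl on an aromatic carbon of the five-membered ring gives an at least 1.2-fold higher number from compound 1 to compound 3 (0.08 log units; that floor lies within the scatter). Compound 3 gives only a limit, not a number, so this first look at the position shows no gain in activity from the change, while the printed floor of the step is too small to establish a real loss. The read-out now offers little room for comparing compounds at this position: the limit of > 100000 nM in this assay, at which 2 of the 3 values shown sit.

From the compounds shown here alone, how far compound 3 lies past that limit stays open, and with it the true size of the step from benzyl to phenyl. Also open, going by these compounds, is whether a phenethyl group at the same place, or a phenyl carrying an amine or a carboxylic acid, would bring the number down into the range the assay can read.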